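Trifluoromethyl in place of nitro: compound 4

This account rests on a few compounds, and the source may have more. Where it says the series, first, only, none or still open, it means among the compounds named here.

Values in an ADME assay on cells (spleen, Mus musculus, strain C57BL/6) for inhibition, read by flow cytometry and propidium iodide staining, with a stated time of 24 h, at 37 degrees C; on this read-out lower numbers stand for an effect already at smaller amounts and higher numbers for an effect only at larger amounts of compound:
compound 1 `Nc1cccc(-c2cn(CC(=O)NCc3ccccc3)nn2)c1`: 800 uM
compound 2 `Cc1ccc(-c2cn(CC(=O)NCc3ccccc3)nn2)cc1`: "non-toxic" (no number reported)
compound 3 `O=C(Cn1cc(-c2cccc([N+](=O)[O-])c2)nn1)NCc1ccccc1`: > 2000 uM
compound 4 `O=C(Cn1cc(-c2cccc(C(F)(F)F)c2)nn1)NCc1ccccc1`: not yet measured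

Compound 3 stands at the limit of > 2000 uM in this assay, at which 1 of the 3 values shown sits. This is a limit and not a number. Compound 4 carries trifluoromethyl in place of nitro on an aromatic carbon, (trifluoromethyl in place of nitro on an aromatic carbon). Among the compounds with values here, no measured step makes this exchange. The nearest is an at least 2.5-fold higher number from compound 1 to compound 3 (0.39 log units; beyond the scatter), with nitro in place of amino, and it lies beyond the scatter. Compound 2 offers no number to size a step. In this assay, as far as these compounds go, no step beyond the scatter is therefore expected, and the direction stays open. The expected step is a number no higher from compound 3 to compound 4 (the limit leaves the size open). For compound 4 the estimated value is 2000 uM. The expected range for compound 4 runs from 700 uM to 4000 uM.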

Compound 4, concentration for half-maximal effect: "non-toxic" (no number reported)
Compound 4: no number reported; the estimate stays without a comparison.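

Compound 4 is reported in this assay only as "non-toxic", without a number, so no step can be read from compound 3 to compound 4. The compounds shown leave open whether trifluoromethyl in place of nitro shifts the value in this assay at all.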